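Swapping the Sulfonamide Cap on a Macrocyclic Calpain Aldehyde

This account rests on a few compounds, and the source may have more. Where it says the series, first, only, none or still open, it means among the compounds named here.

Measured compounds:
compound 1 `CC(C)[C@@H]1NC(=O)[C@@H](NS(=O)(=O)c2ccc(F)cc2)Cc2ccc(cc2)OCCCC[C@@H](C=O)NC1=O` — 280 nM
compound 2 `CC(C)[C@@H]1NC(=O)[C@@H](NS(=O)(=O)c2ccc(F)cc2)Cc2ccc(cc2)OCCCCSC[C@@H](C=O)NC1=O` — 2400 nM

In an assay on isolated protein for inhibition of Calpain-2 catalytic subunit (Homo sapiens), read by fluorescence (a higher number here means a weaker inhibitor, a lower number a stronger inhibitor), compound 1 gives 280 nM, the lowest of the two numbers shown. Compound 2 gives 2400 nM, a gap beyond the scatter. Compound 3 `CC(C)[C@@H]1NC(=O)[C@@H](NC(=O)OCc2ccccc2)Cc2ccc(cc2)OCCCC[C@@H](C=O)NC1=O` is not yet measured. It differs from compound 1 by benzyloxycarbonyl in place of (4-fluorophenyl)sulfonyl on an amine nitrogen. Among the measured compounds shown here, no measured pair makes this change, so its size is unknown from these data. Compound 3 is expected to shift only a little, an estimated 1.4-fold lower number from compound 1 to compound 3 (0.15 log units; within the scatter), possibly toward a lower number. The estimate for compound 3 is 200 nM, with a range from 50 nM to 800 nM.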

Compound 3, half-maximal inhibitory concentration: 85 nM
Beside the measured number, compound 3's estimate is 2.4-fold (0.37 log units) above it; the measured number falls inside the stated range.
By their numbers in this assay, from the lowest: compound 3; then compound 1; then compound 2.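

Among the compounds shown here, compound 1 and compound 2 share the (4-fluorophenyl)sulfonyl cap, so only this change tests the amine nitrogen. In this assay, benzyloxycarbonyl gives a 3.3-fold lower number from compound 1 to compound 3 (0.52 log units; beyond the scatter), showing that the cap affects inhibition even though both groups match in heavy atoms and hydrogen-bond acceptors. Nothing here explains the difference.

Going by these compounds, it remains open whether an acetyl group or a 4-fluorobenzyloxycarbonyl group would give a lower or higher number. Also open, on these data alone, is whether benzyloxycarbonyl would give a similar step on the sulfur-containing chain of compound 2.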